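The source may report more compounds than this note shows. Statements on the series, on what has been measured and on what is new or still open speak of the compounds shown alone.

Three compounds share one core and differ only in the aryl ring joined to an aromatic carbon of that core. Compound 1 `N#Cc1c(-c2ccc(F)cc2)c(C#N)c(=O)n(/N=C/c2cn(-c3ccccc3)nc2-c2ccccc2)c1N` carries a 4-fluorophenyl group. In an ADME assay on NIH3T3 cells (Mus musculus) for cytotoxicity, read by MTT assay (on this read-out lower numbers stand for stronger inhibition and higher numbers for weaker inhibition), compound 1 reaches only a limit of the assay, > 200 ug/mL. Compound 2 `COc1cc(-c2c(C#N)c(N)n(/N=C/c3cn(-c4ccccc4)nc3-c3ccccc3)c(=O)c2C#N)cc(OC)c1OC` carries a 3,4,5-trimethoxyphenyl group, and in this assay compound 2 gives 64 ug/mL. Compound 3 `N#Cc1c(-c2ccccc2[N+](=O)[O-])c(C#N)c(=O)n(/N=C/c2cn(-c3ccccc3)nc2-c2ccccc2)c1N` carries a 2-nitrophenyl group. In this assay compound 3 again gives only a limit, > 200 ug/mL. Compound 3 thus sits at the limit of > 200 ug/mL in this assay, at which 2 of the 3 values shown sit. Among the compounds with values here, compound 2 is the one compound with a readable number. The measured steps are an at least 3.1-fold lower number from compound 1 to compound 2 (0.49 log units; beyond the scatter), an at least 3.1-fold higher number from compound 2 to compound 3 (0.49 log units; beyond the scatter), and a step that the two limits leave unreadable from compound 1 to compound 3.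

Compound 4 `N#Cc1c(-c2ccccc2C(F)(F)F)c(C#N)c(=O)n(/N=C/c2cn(-c3ccccc3)nc2-c2ccccc2)c1N` differs from compound 3 by trifluoromethyl in place of nitro on an aromatic carbon. Within the data shown here, no measured step exchanges a nitro for a trifluoromethyl, so the three steps bear on it only loosely: the fluorophenyl and nitrophenyl rings both leave the number at the limit, and only the trimethoxyphenyl ring lowers it. The step this estimate means, a number no higher from compound 3 to compound 4 (the limit leaves the size open), is expected to be none beyond the scatter. For compound 4 the expected value in this assay is 200 ug/mL, within 80 ug/mL to 450 ug/mL.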

Compound 4, half-maximal inhibitory concentration: 56 ug/mL
Estimate against measurement, compound 4: 3.6-fold (0.55 log units) above; measured number outside the range, below it.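

Swapping a single group on this ring changes the outcome in this assay: trifluoromethyl in place of nitro gives an at least 3.5-fold lower number from compound 3 to compound 4 (0.55 log units; beyond the scatter), so a readable number here does not depend on the 3,4,5-trimethoxyphenyl ring. The 2-(trifluoromethyl)phenyl ring also separates from the 4-fluorophenyl ring, with an at least 3.5-fold lower number from compound 1 to compound 4 (0.55 log units; beyond the scatter), while against the trimethoxyphenyl ring it shows a 1.1-fold lower number from compound 2 to compound 4 (0.06 log units; within the scatter), so these two rings cannot be told apart here. Compound 1 and compound 3 remain at a limit of the assay rather than at a number: the limit of > 200 ug/mL in this assay, at which 2 of the 4 values shown sit.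

From the compounds shown here alone, what a methyl group, a chlorine atom or a methoxy group would give at this same place on the ring remains open. So does how far compound 1 and compound 3 actually lie beyond their limit.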